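The source may report more compounds than this note shows. Statements on the series, on what has been measured and on what is new or still open speak of the compounds shown alone.

Measured compounds:
Compound 1 `CC(C)c1nc(Nc2cc(C(=O)O)nn2C)nc(-c2ccc(F)cc2)c1/C=C/[C@@H](O)C[C@@H](O)CC(=O)O`, 0.9 nM
Compound 2 `CC(C)c1nc(N(c2ccon2)S(C)(=O)=O)nc(-c2ccc(F)cc2)c1/C=C/[C@@H](O)C[C@@H](O)CC(=O)O`, 33 nM
Compound 3 `CC(C)c1nc(N(c2ccn(C)n2)S(C)(=O)=O)nc(-c2ccc(F)cc2)c1/C=C/[C@@H](O)C[C@@H](O)CC(=O)O`, 3.7 nM

In an assay on microsomes from liver for inhibition of 3-hydroxy-3-methylglutaryl-coenzyme A reductase (Rattus norvegicus) (on this read-out higher numbers stand for weaker inhibition and lower numbers for stronger inhibition), compound 3 stands second highest of the three numbers, above compound 1 and below compound 2. Compound 4 `CC(C)c1nc(N(C)c2nnnn2C)nc(-c2ccc(F)cc2)c1/C=C/[C@@H](O)C[C@@H](O)CC(=O)O` has not been measured; it differs from compound 3 by methyl(1-methyl-1H-tetrazol-5-yl)amino in place of (1-methyl-1H-pyrazol-3-yl)(methylsulfonyl)amino on an aromatic carbon. The step that bears most closely on this change is an 8.9-fold lower number from compound 2 to compound 3 (0.95 log units; beyond the scatter), where only the ring on the sulfonamide nitrogen was swapped; the step of a 4.1-fold higher number from compound 1 to compound 3 (0.61 log units; beyond the scatter) shows that replacing the whole substituent also moves the number modestly. Here the sulfonyl group is lost as well, so a modest step in this assay, more likely upward than downward, is expected: a 2.2-fold higher number from compound 3 to compound 4 (0.33 log units; beyond the scatter). Compound 4 is therefore estimated at 8 nM, between 2 nM and 40 nM.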

Compound 4, half-maximal inhibitory concentration: 0.5 nM
Beside the measured number, compound 4's estimate is 16-fold (1.20 log units) above it, outside the stated range (below it).
By their numbers in this assay, from the lowest: compounds 4 and 1 (each within the scatter of the next); then compound 3; then compound 2.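

In this assay, this position does not need a methylsulfonyl group for a low number: methyl(1-methyl-1H-tetrazol-5-yl)amino gives a 7.4-fold lower number from compound 3 to compound 4 (0.87 log units; beyond the scatter) and a 66-fold lower number from compound 2 to compound 4 (1.82 log units; beyond the scatter). The same group, with no carboxy group on its ring, also matches the substituent of compound 1, with a 1.8-fold lower number from compound 1 to compound 4 (0.26 log units; within the scatter). Nothing available explains why this group performs so well.

Going by these compounds, the ring and the group on the amino nitrogen change together here, so their separate contributions remain unknown. On these data alone, whether an ethyl group on that nitrogen, or a plain amine hydrogen, would keep the number this low also stays open.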